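The source may hold more compounds than are shown below. What is called first, only, known or untested is meant among the compounds shown, and "the series" means these compounds.

In a functional assay for inhibition, with Homo sapiens as the target (a higher number here means weaker binding, a lower number tighter binding), compound 1 `CSc1ccc(OC(C)(C)C2OCC(C/C=C\CCC(=O)O)C(c3cccnc3)O2)c([N+](=O)[O-])c1` gives 4.47 nM, while compound 2 `COc1ccccc1OC(C)(C)C1OCC(C/C=C\CCC(=O)O)C(c2cccnc2)O1` gives 224 nM. Compound 2 therefore has the higher of the two numbers, which means the weaker binding of the pair. The next compound, compound 3 `CC(C)(Oc1ccc(F)cc1[N+](=O)[O-])C1OCC(C/C=C\CCC(=O)O)C(c2cccnc2)O1`, keeps the shared core and changes only the aromatic group: 4-fluoro-2-nitrophenyl in place of 2-methoxyphenyl on an oxygen on a saturated carbon. In words, 4-fluoro-2-nitrophenyl replaces 2-methoxyphenyl on an oxygen on a saturated carbon.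

Among the compounds with values here, only one measured step bears on this change. That step, a 50-fold higher number from compound 1 to compound 2 (1.70 log units; beyond the scatter), is large and lies beyond the scatter, and it also swaps the group on this oxygen. Compound 1 carries a nitro-bearing phenyl group there, as compound 3 does, so the change from compound 2 to compound 3 looks like a partial return towards compound 1. Within the data shown here, no measured compound shows what the fluorine itself does, so the return may be incomplete. The expected change is large and towards a lower number in this assay: a 19-fold lower number from compound 2 to compound 3 (1.27 log units; beyond the scatter). For compound 3 the estimated value is 12 nM, with an expected range from 3 nM to 50 nM.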

Compound 3, dissociation constant: 2.51 nM
Compound 3: the middle estimate sits 4.8-fold (0.68 log units) above what was measured; the measured number lies below the stated range.
By their numbers in this assay, from the lowest: compounds 3 and 1 (each within the scatter of the next); then compound 2.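

Replacing 2-methoxyphenyl with 4-fluoro-2-nitrophenyl on this oxygen gives an 89-fold lower number from compound 2 to compound 3 (1.95 log units; beyond the scatter), so a large difference from compound 2 now appears with two different nitro-bearing phenyl groups, those of compound 1 and compound 3, and not with just one. Fluoro in place of methylsulfanyl on an aromatic carbon gives a 1.8-fold lower number from compound 1 to compound 3 (0.25 log units; within the scatter), so exchanging these two groups produces no readable difference between compound 1 and compound 3. Read together, and for these three compounds only, the two steps tie the large change to what compound 1 and compound 3 share against compound 2, and not to the group that differs between them.

Each step away from compound 2 removes the methoxy group and adds a nitro group at once, so these compounds cannot separate the two events; a plain phenyl group, a 2-nitrophenyl group without the fluoro, or an amine or a nitrile in place of the nitro group would begin to pull them apart. Nothing measured here gives a reason for the size of these steps.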